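Aryl piperidine acetanilides: heteroaryl replacement at the piperidine

The source may hold more compounds than are shown below. What is called first, only, known or untested is meant among the compounds shown, and "the series" means these compounds.

Measured compounds in a functional assay on HEK293 cells for agonist activity at D(4) dopamine receptor (Homo sapiens), read by FLIPR; a lower number here means that less compound is needed, a higher number that more compound is needed for the effect:
compound 1 `COc1ccccc1C1CCN(CC(=O)Nc2cccc(C)c2)CC1`: 420 nM
compound 2 `Cc1cccc(NC(=O)CN2CCC(c3cccc(F)c3)CC2)c1`: 512 nM
compound 3 `Cc1cccc(NC(=O)CN2CCC(c3ccccc3)CC2)c1`: 170 nM

Compound 3 gives the lowest number of the three; its nearest neighbour is compound 1 by a 2.5-fold lower number from compound 1 to compound 3 (0.39 log units; beyond the scatter), and compound 2 lies further off by a 3.0-fold lower number from compound 2 to compound 3 (0.48 log units; beyond the scatter). Compound 4 `Cc1cccc(NC(=O)CN2CCC(c3ccc(O)cn3)CC2)c1` carries 5-hydroxypyridin-2-yl in place of phenyl on a saturated ring carbon. Within the data shown here, no measured step exchanges the aromatic ring itself for a different ring; the steps that bear on this position are a 2.5-fold lower number from compound 1 to compound 3 (0.39 log units; beyond the scatter) and a 3.0-fold lower number from compound 2 to compound 3 (0.48 log units; beyond the scatter), which show that a substituent on that ring costs a modest amount, while a 1.2-fold higher number from compound 1 to compound 2 (0.09 log units; within the scatter) is within the scatter. A hetero ring bearing a hydroxyl is a larger departure than either, so a modest-to-clear rise in this assay is expected: a 4.7-fold higher number from compound 3 to compound 4 (0.67 log units; beyond the scatter). Compound 4 is estimated at 800 nM, range 250 nM to 3000 nM.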

Compound 4, half-maximal effective concentration: 3.8 nM
For compound 4 the middle estimate is 210-fold (2.32 log units) above the measured one; measured number below the stated range.
By their numbers in this assay, from the lowest: compound 4; then compound 3; then compounds 1 and 2 (each within the scatter of the next).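

In this assay the substituent changes on the phenyl ring moved the number only modestly, whereas exchanging the ring itself for 5-hydroxypyridin-2-yl gives a 45-fold lower number from compound 3 to compound 4 (1.65 log units; beyond the scatter) as a large step. The same exchange is also large from either substituted phenyl, with a 130-fold lower number from compound 2 to compound 4 (2.13 log units; beyond the scatter) and a 110-fold lower number from compound 1 to compound 4 (2.04 log units; beyond the scatter) as the steps, so at this saturated ring carbon the identity of the aromatic ring matters far more than the substituents compared earlier. No evidence at hand accounts for the size of these steps.

As far as these compounds go, the ring nitrogen and the hydroxyl enter together, so the share of each remains open. From the compounds shown here alone, whether plain pyridin-2-yl, 5-methoxypyridin-2-yl or 5-aminopyridin-2-yl would keep the low number is also open.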